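Methylamine Step in Benzophenone and Chromene Anilide Series

This account rests on a few compounds, and the source may have more. Where it says the series, first, only, none or still open, it means among the compounds named here.

Measured compounds: compound 1 `CNCC(=O)Nc1cc(OC)ccc1C(=O)c1cc(OC)c(OC)c(OC)c1`, 580 nM; compound 2 `COc1ccc(C(=O)c2cc(OC)c(OC)c(OC)c2)c(NC(=O)CN(C)C)c1`, 580 nM; compound 3 `C=C(c1ccc(OC)cc1NC(=O)CN)c1ccc(OC)c2c1C=CC(C)(C)O2`, 400 nM.

In a functional assay on A2780 cells (Homo sapiens) for antiproliferative activity, read by MTT assay, with a stated time of 48 h (a lower number here means a stronger inhibitor, a higher number a weaker inhibitor), compound 1 gives 580 nM and compound 2 gives 580 nM. The change between them is methyl in place of hydrogen on an amine nitrogen, and the step is no change at the digits printed from compound 1 to compound 2 (within the scatter). Compound 3 gives 400 nM in this assay; against compound 1 and compound 2 its value sits within the scatter, so no order among the three can be read. The difference between the core of compound 3 and the core of compound 1 is not broken down here.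

Compound 4 `C=C(c1ccc(OC)cc1NC(=O)CNC)c1ccc(OC)c2c1C=CC(C)(C)O2` is not yet measured. It differs from compound 3 by methyl in place of hydrogen on an amine nitrogen. This is the same kind of change as that from compound 1 to compound 2, but not the same: there the amine nitrogen carried two saturated chain carbons, here it carries one saturated chain carbon. Because no change at the digits printed from compound 1 to compound 2 (within the scatter) showed no movement, the expected step for compound 4 is no change at the digits printed from compound 3 to compound 4 (within the scatter), resting on a single precedent. Compound 4 is thus expected to give about 400 nM in this assay, likely between 200 nM and 800 nM.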

Compound 4, half-maximal inhibitory concentration: 720 nM
The estimate for compound 4 lay 1.8-fold (0.26 log units) below the measured number; the range from low to high includes it.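

In this assay the methyl on the amine nitrogen of the core of compound 3 gives a 1.8-fold higher number from compound 3 to compound 4 (0.26 log units; within the scatter), so on this core too the step stays inside the scatter. Set side by side, the two steps cannot be told apart: the same change on two cores in this assay, no change at the digits printed (within the scatter) from compound 1 to compound 2 and a 1.8-fold higher number (0.26 log units; within the scatter) from compound 3 to compound 4, 1.8-fold (0.26 log units) apart, within the scatter of two such steps. This shows that the change carries from the core of compound 1 to the core of compound 3 without a step that stands clear of the scatter; it does not show that the two cores respond identically or that the methyl is without any effect on either, and two pairs are a narrow base for a rule across the series.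

The compounds shown leave open whether an ethyl or a longer chain on this nitrogen would give a step beyond the scatter on either core. Also open, as far as these compounds go, is what a ring amine such as morpholine or piperidine, or a carboxylic acid in place of the amine, would do in this assay.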